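Swapping the pyridine arm for a larger fused bicyclic group

The source may hold more compounds than are shown below. What is called first, only, known or untested is meant among the compounds shown, and "the series" means these compounds.

In an ADME assay on BaF3 cells (Mus musculus) for cytotoxicity (on this read-out lower numbers stand for an effect already at smaller amounts and higher numbers for an effect only at larger amounts of compound), compound 2 `FC(F)(F)Oc1ccc(Nc2cc(-c3ccncc3)ncn2)cc1` gives > 10000 nM, which is a limit of the assay rather than a number. Compound 1 `FC(F)(F)c1ccc(Nc2cc(-c3ccncc3)ncn2)cc1` gives > 10000 nM in this assay, again only a limit. Going by the values given here, the only measured step, a step that the two limits leave unreadable from compound 1 to compound 2, is therefore unreadable, and the limit of > 10000 nM in this assay, at which 2 of the 2 values shown sit, leaves no pattern to lean on. Compound 3 `FC(F)(F)Oc1ccc(Nc2cc(-c3ccnc4[nH]ccc34)ncn2)cc1` differs from compound 2 by a group of 9 heavy atoms (7 carbon, 2 nitrogen; one five-membered aromatic ring with 1 hetero atom, one six-membered aromatic ring with 1 hetero atom) in place of a group of 6 heavy atoms (5 carbon, 1 nitrogen; one six-membered aromatic ring with 1 hetero atom), on an aromatic carbon. Among the compounds with values here, no measured step bears on this change, so no direction beyond the scatter is expected. Compound 3 is estimated at 8000 nM, between 1500 nM and 30000 nM. That estimate means an expected step of an at least 1.2-fold lower number from compound 2 to compound 3 (0.09 log units; that floor lies within the scatter).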

Compound 3, half-maximal effective concentration: 6850 nM
For compound 3 the middle estimate is 1.2-fold (0.07 log units) above the measured one; the range from low to high includes it.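

Compound 1 and compound 2 each stop at a limit of the assay, not a number: the limit of > 10000 nM in this assay, at which 2 of the 3 values shown sit. Going by these compounds alone, compound 3 brings the first true number, so this aromatic carbon next to the ring nitrogen is the first place where a change can be read at all, although the step from compound 1 to compound 2 still cannot. In this assay, the larger fused group in place of pyridin-4-yl gives an at least 1.4-fold lower number from compound 2 to compound 3 (0.16 log units; that floor lies within the scatter), so the floor of this change does not clear the scatter. On these data alone, whether an amine or a morpholine at this carbon would move the number further stays open. So does whether the fused group would give a similar number with trifluoromethyl in place of trifluoromethoxy.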